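Adding a cyclopropyl group to a thiophene-bearing imine

This account rests on a few compounds, and the source may have more. Where it says the series, first, only, none or still open, it means among the compounds named here.

Measured so far:
compound 1 `c1ccc(C(/N=C2\CCCCCN2)C2CC2)cc1` gives 51%
compound 2 `c1csc(C/N=C2\CCCCCN2)c1` gives 19%

Both compounds were tested in a functional assay on the whole organism (plasma, strain Sprague-Dawley) with Rattus norvegicus as the target, with a stated time of 2 h, at a dose of 100 mg/kg by the oral route; on this read-out higher numbers stand for a stronger effect at the one dose given and lower numbers for a weaker effect. Compound 2 stands lowest of the two numbers, and compound 1 lies a step higher, a gap beyond the usual scatter. Compound 3 `c1csc(C(/N=C2\CCCCCN2)C2CC2)c1` is not yet measured. It differs from compound 2 by cyclopropyl in place of hydrogen on a saturated chain carbon bound to an aromatic carbon and a double-bonded nitrogen. Within the data shown here, no measured pair shows this same change alone, so the expected step of a number 21 percentage points higher from compound 2 to compound 3 (beyond the scatter) is a guess, leaning upward since compound 1, which carries the same group, gives 51%. Compound 3 is estimated at 40%, within 20% to 60%.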

Compound 3, a percentage reported as inhibition, in the whole organism at one dose (the size of the read-out at that dose, not a potency): 44%
The estimate for compound 3 lay 4 percentage points below the measured number; low and high end bracket the measured number.
By their numbers in this assay, from the lowest: compound 2; then compounds 3 and 1 (each within the scatter of the next).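

In this assay, among these compounds, cyclopropyl in place of hydrogen on the saturated chain carbon gives a number 25 percentage points higher from compound 2 to compound 3 (beyond the scatter) and so provides the first reading of this change alone. With cyclopropyl present, thiophen-2-yl in place of phenyl gives a number 7 percentage points lower from compound 1 to compound 3 (within the scatter) and so does not separate the two rings on this read-out. Nothing available explains the cyclopropyl step.

On these data alone, it remains open what a methyl group or a longer chain would give on this same carbon. As far as these compounds go, whether cyclopropyl brings a similar step to the phenyl compounds also remains open.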